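Aryl swap on the five-membered ring of compound 1

The compounds below may be only part of what the source reports. "The series", "measured", "known", "first", "only" and "open" are said of these compounds alone.

Measured so far in an ADME assay on BJ cells (Homo sapiens), read by MTT assay, with a stated time of 72 h; on this read-out lower numbers stand for stronger inhibition and higher numbers for weaker inhibition:
- compound 1, `COc1ncnc2c1c(-c1ccsc1)cn2[C@@H]1O[C@H](CO)[C@@H](O)[C@H]1O`: 64300 nM
- compound 2, `CN(C)c1ncnc2c1c(-c1ccsc1)cn2[C@@H]1O[C@H](CO)[C@@H](O)[C@H]1O`: > 100000 nM (a limit)
- compound 3, `COc1nc(N)nc2c1c(-c1ccsc1)cn2[C@@H]1O[C@H](CO)[C@@H](O)[C@H]1O`: > 100000 nM (a limit)

Compound 1 carries the only number shown; the other two values are limits. Compound 2 sits at the limit of > 100000 nM in this assay, at which 2 of the 3 values shown sit, and gives no number. Compound 3 sits at that same limit. The steps of an at least 1.5-fold higher number from compound 1 to compound 2 (0.19 log units; that floor lies within the scatter) and an at least 1.5-fold higher number from compound 1 to compound 3 (0.19 log units; that floor lies within the scatter) therefore only set floors, and both alter positions other than the one now varied. Compound 4 `COc1ncnc2c1c(-c1ccccc1)cn2[C@@H]1O[C@H](CO)[C@@H](O)[C@H]1O` differs from compound 1 by phenyl in place of thiophen-3-yl on an aromatic carbon. Among the compounds with values here, no measured step touches this position, so no shift beyond the scatter is expected, and the step of a 1.1-fold higher number from compound 1 to compound 4 (0.04 log units; within the scatter) is the estimate. Compound 4 is expected to give 70000 nM, between 20000 nM and 200000 nM.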

Compound 4, half-maximal inhibitory concentration: > 100000 nM
Compound 4: only a limit was reported; the forecaster's own chance of this, stated with the estimate: 35%; at least 1.4-fold (0.15 log units) between middle value and limit.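

Phenyl in place of thiophen-3-yl is the first change shown at this position, and in this assay compound 4 gives only a limit, > 100000 nM. The step is an at least 1.5-fold higher number from compound 1 to compound 4 (0.19 log units; that floor lies within the scatter), so it sets a floor and no size for this change. Compound 1 remains the only compound with a number, and the values gather at one ceiling: the limit of > 100000 nM in this assay, at which 3 of the 4 values shown sit.

As far as these compounds go, how far compound 4 lies past that limit stays open. Also open, from the compounds shown here alone, is what a furan-3-yl group, or a phenyl carrying a carboxylic acid, would give at this position.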